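From a Nitrile to Two Fluorines on a Shared Core

A few compounds are considered here, and "the series" means these few. Any claim that something is new, unique, unknown or untested is made for them only; others in the source may bear on it.

Compound 1 `COc1ccc(S(=O)(=O)N2CCc3cccc(-c4ccc(C#N)cc4)c32)cc1` stands lowest among three measured compounds. In a functional assay on HT-29 cells (Homo sapiens) for inhibition, with a stated time of 72 h (a lower number here means a stronger inhibitor, a higher number a weaker inhibitor), compound 1 gives 24.2 nM. Compound 3 `COc1ccc(S(=O)(=O)n2ccc3cccc(-c4ccc(F)cc4)c32)cc1` gives 196 nM in this assay, a higher number that lies beyond the scatter. Compound 2 `COc1ccc(S(=O)(=O)N2CCc3cccc(-c4c(F)c(F)c(F)c(F)c4F)c32)cc1` gives 3900 nM in this assay, the highest number of the three and far beyond the scatter from compound 1. Going by the values given here, each of compounds 2 and 3 differs from compound 1 in more than one place, so no single-change step between measured compounds is known here; the two values of compound 2 and compound 3 only show that both fall well behind compound 1.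

Compound 4 `COc1ccc(S(=O)(=O)N2CCc3cccc(-c4ccc(F)c(F)c4)c32)cc1` differs from compound 1 in one place: 3,4-difluorophenyl in place of 4-cyanophenyl on an aromatic carbon. Compound 3, which carries a fluorinated ring on a related core, gives 196 nM, and compound 2, with a fully fluorinated ring, gives 3900 nM. On that basis the step is expected to raise the number beyond the scatter, giving a 6.2-fold higher number from compound 1 to compound 4 (0.79 log units; beyond the scatter). Compound 4 is therefore estimated at 150 nM, with a range from 40 nM to 600 nM.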

Compound 4, half-maximal inhibitory concentration: 57 nM
For compound 4 the middle estimate is 2.6-fold (0.42 log units) above the measured one; measured number inside the range.
By their numbers in this assay, from the lowest: compound 1; then compound 4; then compound 3; then compound 2.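

Going by these compounds alone, replacing 4-cyanophenyl with 3,4-difluorophenyl on this aromatic carbon gives a 2.4-fold higher number from compound 1 to compound 4 (0.37 log units; beyond the scatter) in this assay and provides the first single-change reading at this position on the shared core. The step is beyond the scatter but modest: without the nitrile, compound 4 still gives 57 nM and so stays in the nanomolar range, which shows that the nitrile is not essential for activity here. No measurement offered here explains why the number rises with this change.

As far as these compounds go, whether a phenyl ring carrying an amine or a carboxylic acid in place of the nitrile would hold the number close to that of compound 1 remains open. Also open, from the compounds shown here alone, is how much each of the two fluorines in compound 4 contributes to its number.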